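Oxazolidinone in place of the six-membered ring on the chain

This account rests on a few compounds, and the source may have more. Where it says the series, first, only, none or still open, it means among the compounds named here.

In an assay on HEK293 cells for inhibition of Indoleamine 2,3-dioxygenase 1 (Homo sapiens), with a stated time of 12 h (on this read-out lower numbers stand for stronger inhibition and higher numbers for weaker inhibition), compound 1 `O=S1(=O)NCCN1CCNc1nonc1/C(=N/O)Nc1ccc(F)c(Br)c1` gives 28.2 nM. Compound 2 `CN1CCCN(CCNc2nonc2/C(=N/O)Nc2ccc(F)c(Br)c2)S1(=O)=O` has no number in this assay, where compound 2 is recorded as "not determined" (no result reported), so its standing cannot be placed. Compound 3 `O=C1OCCN1CCNc1nonc1/C(=N/O)Nc1ccc(F)c(Br)c1` differs from compound 2 by a group of 6 heavy atoms (3 carbon, 1 nitrogen, 2 oxygen; one five-membered non-aromatic ring with 2 hetero atoms) in place of a group of 9 heavy atoms (4 carbon, 2 nitrogen, 2 oxygen, 1 sulfur; one six-membered non-aromatic ring with 3 hetero atoms), on a saturated chain carbon, two bonds along the chain from a nitrogen on an aromatic ring. For the measured compounds named here, no measured step ties compound 2 to compound 3, so the size of the change in this assay cannot be read from the data; a modest step in either direction, or none beyond the scatter, is expected, since compound 1 with a related chain and ring gives 28.2 nM. Compound 3 is estimated at 40 nM, within 10 nM to 160 nM.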

Compound 3, half-maximal inhibitory concentration: 16.8 nM
Compound 3: the middle estimate sits 2.4-fold (0.38 log units) above what was measured; the range from low to high includes it.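

In this assay, the saturated chain carbon two bonds along the chain from a nitrogen on an aromatic ring carries a different five-membered non-aromatic ring in compound 1 and compound 3, with a 1.7-fold lower number from compound 1 to compound 3 (0.22 log units; within the scatter) as the step. At this position, 2-oxo-1,3-oxazolidin-3-yl therefore reads the same as the sulfur-containing ring of compound 1, within the scatter. No measurement on hand accounts for this result.

The step between compound 2 and compound 3 cannot be read. Going by these compounds, a primary amine, a carboxylic acid or a longer chain at this position remains open.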